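A few compounds are considered here, and "the series" means these few. Any claim that something is new, unique, unknown or untested is made for them only; others in the source may bear on it.

Working notes on the series. Compound 1 `Oc1ccc(O)c(/C=N/c2ccc(OCc3ccccc3)cc2)c1` gives 1230 nM in an assay on isolated protein for inhibition of Amine oxidase [flavin-containing] B (Homo sapiens), read by fluorescence and Amplex Red, with stated times of 15 min and 20 min (on this read-out lower numbers stand for stronger inhibition and higher numbers for weaker inhibition), the lowest number of the three measured. Compound 2 `Oc1ccc(/C=N/c2ccc(OCc3ccccc3)cc2)c(O)c1` gives 6780 nM and compound 3 `Cc1ccc(/C=N/c2ccc(OCc3ccccc3)cc2)c(O)c1` gives 24400 nM in this assay. The step of a 5.5-fold higher number from compound 1 to compound 2 (0.74 log units; beyond the scatter) and the step of a 20-fold higher number from compound 1 to compound 3 (1.30 log units; beyond the scatter) both raise the number, as does the step of a 3.6-fold higher number from compound 2 to compound 3 (0.56 log units; beyond the scatter). Compound 4 `O=[N+]([O-])c1ccc(O)c(/C=N/c2ccc(OCc3ccccc3)cc2)c1` differs from compound 1 by nitro in place of hydroxy on an aromatic carbon. Every measured step that moved or exchanged that hydroxy raised the number, the exchange for methyl modestly and the combined change from compound 1 to compound 3 by a large amount. A modest rise is therefore expected for compound 4 in this assay, a 4.1-fold higher number from compound 1 to compound 4 (0.61 log units; beyond the scatter). The estimate for compound 4 is 5000 nM, within a range from 1500 nM to 16000 nM.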

Compound 4, half-maximal inhibitory concentration: 60900 nM
Compound 4: the middle estimate sits 12-fold (1.09 log units) below what was measured, outside the stated range (above it).
By their numbers in this assay, from the lowest: compound 1; then compound 2; then compound 3; then compound 4.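

Unlike the earlier steps, which moved the hydroxy or changed the ring in more than one way, this step exchanges it in place, para to a hydroxy group, and in this assay nitro in place of hydroxy gives a 50-fold higher number from compound 1 to compound 4 (1.69 log units; beyond the scatter). This position therefore tolerates nitro poorly in this series, and compound 4 has the highest number of the four. No available evidence accounts for the rise. Open, going by these compounds, is whether an amine or methoxy at this position would keep the number close to that of compound 1, and so whether losing hydroxy or gaining nitro drives the rise.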